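Chloro for Hydrogen on a Compound at the Assay Limit

The source may hold more compounds than are shown below. What is called first, only, known or untested is meant among the compounds shown, and "the series" means these compounds.

Compound 1 `CCOc1ccc(COc2c(OC)cc(/C=C/C(=O)OCC(=O)Nc3ccccc3)cc2OC)cc1` and compound 2 `COc1ccc(/C=C/C(=O)OCC(=O)Nc2ccccc2)cc1OC` share a core and differ in the group on the aromatic ring bearing the two methoxy groups. In a functional assay on ECa-109 cells (Homo sapiens) for cytotoxicity, read by MTT assay, with a stated time of 72 h (on this read-out lower numbers stand for stronger inhibition and higher numbers for weaker inhibition), compound 1 reaches only the limit of the assay, > 200000 nM. In this assay compound 2 likewise reaches only the limit, > 200000 nM. Compound 2 thus stands at the edge of what this assay can report, and the limit of > 200000 nM in this assay, at which 2 of the 2 values shown sit, shows both measured compounds sitting at that same position. Compound 3 `COc1ccc(/C=C/C(=O)OCC(=O)Nc2ccc(Cl)cc2)cc1OC` differs from compound 2 in one place: chloro in place of hydrogen on an aromatic carbon. No measured pair differs by just this change, and the shown values give no direction for it. The expected step is a number no higher from compound 2 to compound 3 (the limit leaves the size open), none beyond the scatter. Compound 3 is therefore estimated at 200000 nM in this assay, within 50000 nM to 600000 nM, most probably reported again only as a limit.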

Compound 3, half-maximal inhibitory concentration: 81900 nM
The estimate for compound 3 lay 2.4-fold (0.39 log units) above the measured number, and the stated range covers the measured number.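

Among the compounds shown, compound 3 is the first to give a true number in this assay rather than a limit, at 81900 nM, so this position on the anilino ring can change the read-out. Placing chloro on the aromatic carbon, which turns phenyl into 4-chlorophenyl, gives an at least 2.4-fold lower number from compound 2 to compound 3 (0.38 log units; beyond the scatter), a step beyond the usual scatter. The full size of this step stays unknown because compound 2 has only a limit: the limit of > 200000 nM in this assay, at which 2 of the 3 values shown sit.

From the compounds shown here alone, it remains open whether fluoro, methyl, an amine or a carboxylic acid at the same place would lower the number as well, or whether the effect is special to chloro. Going by these compounds, it is also open whether chloro would bring compound 1 off its limit in the same way.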